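Swapping the phenyl group on the shared core

This account rests on a few compounds, and the source may have more. Where it says the series, first, only, none or still open, it means among the compounds named here.

In a functional assay on HOS-TE85 cells (Homo sapiens) for inhibition, read by CCK-8 assay, with a stated time of 72 h (a higher number here means a weaker inhibitor, a lower number a stronger inhibitor), compound 1 `CCN1C(=O)CSC1c1cccc(C(=O)NCCCCc2ccccc2)c1` shows > 1000 nM as a limit and not a number. Compound 2 `COc1cc(F)ccc1N1C(=O)CSC1c1cccc(C(=O)NCCCCc2ccccc2)c1` gives 71.1 nM and compound 3 `O=C(NCCCCc1ccccc1)c1cccc(C2SCC(=O)N2c2ccccc2F)c1` gives 34.1 nM as the lowest number, making it the strongest of the three. Replacing ethyl gave an at least 14-fold lower number from compound 1 to compound 2 (1.14 log units; beyond the scatter) and an at least 29-fold lower number from compound 1 to compound 3 (1.46 log units; beyond the scatter) as large steps. Compound 4 `COc1c(F)cccc1N1C(=O)CSC1c1cccc(C(=O)NCCCCc2ccccc2)c1` carries 3-fluoro-2-methoxyphenyl in place of 2-fluorophenyl on an amide-type nitrogen in a ring, with 3-fluoro-2-methoxyphenyl in place of 2-fluorophenyl on an amide-type nitrogen in a ring as the counted change. It keeps a phenyl group, so those large steps say little here. Compound 2 also has methoxy and fluorine on its phenyl, which makes the modest 2.1-fold lower number from compound 2 to compound 3 (0.32 log units; beyond the scatter) the closest guide. A small rise is expected for compound 4, with a 1.8-fold higher number from compound 3 to compound 4 (0.25 log units; within the scatter) as the estimated step. Compound 4 is estimated at 60 nM with 20 nM to 180 nM as its expected range.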

Compound 4, half-maximal inhibitory concentration: 26.2 nM
Compound 4: the middle estimate sits 2.3-fold (0.36 log units) above what was measured; the range from low to high includes it.
By their numbers in this assay, from the lowest: compounds 4 and 3 (each within the scatter of the next); then compound 2. At a limit, above all of these: compound 1.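

The added methoxy group brings no readable change: 3-fluoro-2-methoxyphenyl in place of 2-fluorophenyl gives a 1.3-fold lower number from compound 3 to compound 4 (0.11 log units; within the scatter), so this position accepts the larger group. Moving the fluorine does count, since 3-fluoro-2-methoxyphenyl in place of 4-fluoro-2-methoxyphenyl gives a 2.7-fold lower number from compound 2 to compound 4 (0.43 log units; beyond the scatter), a modest step beyond the scatter that the earlier compounds could not show. Replacing ethyl gives an at least 38-fold lower number from compound 1 to compound 4 (1.58 log units; beyond the scatter) as a large step, though its starting value is a limit and not a number.

As far as these compounds go, it remains open whether methoxy without fluorine would do as well, and how chlorine or a nitrile on this phenyl would fare.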